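This account rests on a few compounds, and the source may have more. Where it says the series, first, only, none or still open, it means among the compounds named here.

Compound 1 `c1ccc(-c2nc[nH]n2)c(NCC2=NCCN2)c1` is the reference point of this small set. Among the compounds with values here, in an in vitro functional assay on cells (Fibroblast) for agonist activity at Alpha-1B adrenergic receptor (Homo sapiens) (a higher number here means that more compound is needed for the effect, a lower number that less compound is needed), compound 1 gives 5.01 nM, the only full number among the two values reported. The second compound, compound 2 `CC(C)n1nccc1-c1ccccc1NCC1=NCCN1`, yields in this assay only a limit of the assay, < 100000 nM. That value sits at the limit of < 100000 nM in this assay, at which 1 of the 2 values shown sits, so compound 2 contributes no number to compare against. Within the data shown here, no pair of measured compounds differs in a single place, so no measured step is available here.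

The unmeasured compound 3 `c1ccc(-c2cn[nH]c2)c(NCC2=NCCN2)c1` is related to compound 1 by one change: 1H-pyrazol-4-yl in place of 1H-1,2,4-triazol-3-yl on an aromatic carbon. Among the measured compounds shown here, nothing among the measured compounds tells how this exchange acts in this assay. The expected step of a 6.0-fold higher number from compound 1 to compound 3 (0.78 log units; beyond the scatter) is a modest loss, one that could still fall within the scatter of repeated runs. Compound 3 is therefore estimated at 30 nM in this assay, with a range from 5 nM to 300 nM.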

Compound 3, half-maximal effective concentration: 79.4 nM
Compound 3: middle estimate off by 2.6-fold (0.42 log units), on the low side; low and high end bracket the measured number.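

Within the data shown here, the exchange of 1H-1,2,4-triazol-3-yl for 1H-pyrazol-4-yl gives the first measured step at this position, on an aromatic carbon ortho to a group of 7 heavy atoms: in this assay there is a 16-fold higher number from compound 1 to compound 3 (1.20 log units; beyond the scatter), a large step. The two groups have the same heavy-atom count and the same hydrogen-bond donor count, and each is one five-membered aromatic ring, so the position clearly does not treat them as interchangeable, although compound 3 still gives a full number, 79.4 nM, rather than a limit. Nothing among the data shown accounts for the size of this step.

This single step changes the ring atoms and the point of attachment together, so the compounds shown do not separate the two, and they leave open how a 1H-tetrazol-5-yl ring or a carboxylic acid at the same place would read. Compound 2 remains a limit of the assay, < 100000 nM, and it differs from both compound 1 and compound 3 in more than one place, so it adds no comparison.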